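This account rests on a few compounds, and the source may have more. Where it says the series, first, only, none or still open, it means among the compounds named here.

Measured compounds:
compound 1 `N#C/C(=C\c1c(-c2ccccc2)[nH]c2ccccc12)C(N)=O`, 6000 nM;
compound 2 `N#C/C(=C\c1c[nH]c2ccccc12)S(=O)(=O)c1ccccc1`, a limit only: > 100000 nM;
compound 3 `CCOC(=O)/C(=C/c1c(-c2ccccc2)[nH]c2ccccc12)C(=O)c1ccc(Cl)cc1`, 9000 nM.

In a functional assay on MT4 cells (Homo sapiens) for antiproliferative activity, read by MTT assay, with a stated time of 96 h (a lower number here means that less compound is needed, a higher number that more compound is needed for the effect), compound 1 has the lowest of the two numbers, and compound 3 gives a number that differs from it by less than the usual scatter. Compound 2 gives no number at all but only a limit (the limit of > 100000 nM in this assay, at which 1 of the 3 values shown sits). Compound 4 `N#C/C(=C\c1c(-c2ccccc2)[nH]c2ccccc12)C(=O)c1cccs1` is the next step from compound 1: thiophen-2-yl in place of amino on a carbonyl carbon. Among the measured compounds shown here, no measured step of this kind exists among the compounds in hand, so the expected step in this assay is small and within the scatter, as a 1.5-fold lower number from compound 1 to compound 4 (0.18 log units; within the scatter) states. Compound 4 is therefore estimated at 4000 nM, between 1000 nM and 20000 nM.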

Compound 4, half-maximal effective concentration: 400 nM
For compound 4 the middle estimate is 10-fold (1.00 log units) above the measured one; the measured number lies below the stated range.
By their numbers in this assay, from the lowest: compound 4; then compounds 1 and 3 (each within the scatter of the next). At a limit, above all of these: compound 2.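

Thiophen-2-yl in place of amino on a carbonyl carbon gives, in this assay, a 15-fold lower number from compound 1 to compound 4 (1.18 log units; beyond the scatter). Among the compounds shown here, this is the first single-place comparison, and it shows that the number responds strongly to the group on this carbonyl carbon and that the amino donor is not needed for activity here. No measurement shown bears on the cause of this step. From the compounds shown here alone, whether phenyl, furan-2-yl or a short alkyl chain on the same carbonyl carbon would give a similar step stays open, so the role of the thiophene sulfur remains unresolved.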